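The compounds below may be only part of what the source reports. "The series", "measured", "known", "first", "only" and "open" are said of these compounds alone.

Going by the values given here, in an ADME assay on HEK293 cells (Homo sapiens) for cytotoxicity, read by MTT assay, with a stated time of 24 h (a lower number here means a stronger inhibitor, a higher number a weaker inhibitor), three compounds have numbers so far: compound 1 (`CN(C)CCCNc1nc2cc([N+](=O)[O-])ccc2nc1NCc1ccc(Br)cc1`) gives 9.63 ug/mL, compound 2 (`COc1ccc(CNc2nc3ccc([N+](=O)[O-])cc3nc2NCCCN(C)C)cc1`) gives 38.6 ug/mL, and compound 3 (`Cc1ccccc1CNc1nc2ccc([N+](=O)[O-])cc2nc1NCCCN(C)C`) gives 27.6 ug/mL. Compound 3 stands level with compound 2 at the high end of this small set, with a 1.4-fold lower number from compound 2 to compound 3 (0.15 log units; within the scatter). Compound 1 stands apart at the low end, with a 2.9-fold higher number from compound 1 to compound 3 (0.46 log units; beyond the scatter) and a 4.0-fold higher number from compound 1 to compound 2 (0.60 log units; beyond the scatter).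

Compound 4 (`CN(C)CCCNc1nc2cc([N+](=O)[O-])ccc2nc1NCc1cccc(C(F)(F)F)c1`) differs from compound 3 on a saturated chain carbon bound to a nitrogen on an aromatic ring, where 3-(trifluoromethyl)phenyl replaces 2-methylphenyl: 3-(trifluoromethyl)phenyl in place of 2-methylphenyl on a saturated chain carbon bound to a nitrogen on an aromatic ring. Among the compounds with values here, no measured step makes this exact change, so the evidence is indirect. The swaps at this place moved the number beyond the scatter only where compound 1 was involved, and treating the new group as closer to the bromo of compound 1 than to the other two is a judgement. A modest move towards lower numbers is therefore expected, smaller than the steps from compound 1, and it may not clear the scatter. The expected change is a 1.7-fold lower number from compound 3 to compound 4 (0.24 log units; within the scatter). For compound 4 the estimated value is 16 ug/mL, with an expected range from 6.5 ug/mL to 38 ug/mL.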

Compound 4, half-maximal inhibitory concentration: 7.99 ug/mL
Compound 4: middle estimate off by 2.0-fold (0.30 log units), on the high side; the range from low to high includes it.
By their numbers in this assay, from the lowest: compounds 4 and 1 (each within the scatter of the next); then compounds 3 and 2 (each within the scatter of the next).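

In this assay, 3-(trifluoromethyl)phenyl in place of 2-methylphenyl gives a 3.5-fold lower number from compound 3 to compound 4 (0.54 log units; beyond the scatter), and in place of 4-methoxyphenyl it gives a 4.8-fold lower number from compound 2 to compound 4 (0.68 log units; beyond the scatter), so a swap at this place can clear the scatter without compound 1 being involved. In place of 4-bromophenyl, the same group gives a 1.2-fold lower number from compound 1 to compound 4 (0.08 log units; within the scatter), which shows that the low end of this set is not unique to the bromo group. Across these four compounds, the bromo and trifluoromethyl groups sit at the low end and the methyl and methoxy groups at the high end, with no compound going against this split, and nothing available here explains it.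

The identity of the substituent and its place on the ring change together, so these compounds cannot separate the two. On these data alone, how a plain phenyl, a chlorophenyl or a phenyl bearing a nitrile would fall at this place stays open, as does the effect of a longer chain in place of the dimethylaminopropyl chain.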